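From Nitro to Amino, Starting at an Assay Limit

A few compounds are considered here, and "the series" means these few. Any claim that something is new, unique, unknown or untested is made for them only; others in the source may bear on it.

Compound 1 `COc1ccc(C2=C(c3cc(OC)c(OC)c(OC)c3)CC(O)C2=O)cc1[N+](=O)[O-]`: > 100 ug/mL
Compound 2 `COc1ccc(C2=C(c3cc(OC)c(OC)c(OC)c3)CC(O[SiH2]C(C)(C)C)C2=O)cc1[N+](=O)[O-]`: > 100 ug/mL

In an ADME assay on HT-29 cells (Homo sapiens) for cytotoxicity, read by MTT assay, with a stated time of 72 h (a higher number here means a weaker inhibitor, a lower number a stronger inhibitor), compound 1 gives > 100 ug/mL, which is a limit and not a number. Compound 2 gives > 100 ug/mL, also a limit. Both results stand at the same limit: the limit of > 100 ug/mL in this assay, at which 2 of the 2 values shown sit. Among the measured compounds shown here, the only measured change is a step that the two limits leave unreadable from compound 1 to compound 2, made at another place, so it offers no size to carry over. Compound 3 `COc1ccc(C2=C(c3cc(OC)c(OC)c(OC)c3)CC(O)C2=O)cc1N` has amino in place of nitro on an aromatic carbon. For the measured compounds named here, no measured step covers this change, so the estimate is loose, and only a stronger result could be read as a number. The expected change is an at least 10-fold lower number from compound 1 to compound 3 (1.00 log units; beyond the scatter). For compound 3 the estimated value is 10 ug/mL, with an expected range of 0.1 ug/mL to 100 ug/mL.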

Compound 3, half-maximal inhibitory concentration: < 1 ug/mL
Compound 3 gave a limit, no number; the forecaster's own chance of this, stated with the estimate: 25%; middle value at least 10-fold (1.00 log units) away from the limit.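

In this assay, among the compounds shown here, this aromatic carbon is the first place where a change can be read: amino in place of nitro gives an at least 100-fold lower number from compound 1 to compound 3 (2.00 log units; beyond the scatter). Compound 3 gives < 1 ug/mL, which is a limit and not a number. For the compounds shown here, the earlier step at the oxygen cannot be read, so this change alone moves the result away from the limit shared by the earlier compounds. The compounds shown leave open whether a hydroxyl or an acetamide on that same aromatic carbon would give a similar shift, and what number compound 3 would give.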